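Chloro for ethoxy on the pendant ring of compound 3

The source may report more compounds than this note shows. Statements on the series, on what has been measured and on what is new or still open speak of the compounds shown alone.

Going by the values given here, compound 3 `CCOc1ccc(Cc2ccc3ccccc3c2O)cc1` has the lowest number of the three measured so far. In an assay on RBL-1 cells with Polyunsaturated fatty acid 5-lipoxygenase (Rattus norvegicus) as the target (a higher number here means a weaker inhibitor, a lower number a stronger inhibitor), compound 3 gives 62 nM. Compound 1 `CC(C)(C)c1ccc2ccccc2c1O` carries a tert-butyl group on the shared core and in this assay gives 180 nM, a gap beyond the scatter. Compound 2 `Cn1ccnc1Cc1ccc2ccccc2c1O` lies further away still; in this assay compound 2 gives 3500 nM, also beyond the scatter. Among the compounds with values here, neither compound 1 nor compound 2 differs from compound 3 in one place only, so no single-change step is available for comparison.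

Compound 4 `Oc1c(Cc2ccc(Cl)cc2)ccc2ccccc12` differs from compound 3 by chloro in place of ethoxy on an aromatic carbon. Within the data shown here, no measured pair shows this exchange, so its size is unknown here. The expectation is a small step from compound 3 to compound 4 of a 1.8-fold higher number from compound 3 to compound 4 (0.25 log units; within the scatter), toward a somewhat higher number or none beyond the scatter. Compound 4 is therefore estimated at 110 nM in this assay, with a range from 35 nM to 350 nM.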

Compound 4, half-maximal inhibitory concentration: 39 nM
For compound 4 the middle estimate is 2.8-fold (0.45 log units) above the measured one; the range from low to high includes it.
By their numbers in this assay, from the lowest: compounds 4 and 3 (each within the scatter of the next); then compound 1; then compound 2.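

In this assay, the exchange at this place, para to a large group, gives a 1.6-fold lower number from compound 3 to compound 4 (0.20 log units; within the scatter). Going by these compounds alone, this is the first single-change comparison, and it shows that ethoxy and chloro cannot be told apart here, although chloro is the smaller group and carries no hydrogen-bond acceptor. The compounds shown give no information on why the two groups read alike.

Open, going by these compounds, is whether this place responds to any substituent at all, since one exchange within the scatter cannot show how much room for change it offers. A bare hydrogen, an amine, a carboxylic acid or a longer alkoxy chain at this place would show whether the number moves beyond the scatter.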